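Swapping a fused ring for a spiro cyclopropane: solubility

A few compounds are considered here, and "the series" means these few. Any claim that something is new, unique, unknown or untested is made for them only; others in the source may bear on it.

Measured compounds:
- compound 1, `O=C(Nc1ccccc1)c1cnc(NCc2c(F)ccc3c2CCO3)n2cnnc12`: < 1000 nM
- compound 2, `O=C1CCCN1c1cnc(NCc2c(F)ccc3c2CCO3)c2cn[nH]c(=O)c12`: < 2000 nM
- compound 3, `O=C1c2ccccc2CN1c1cnc(NCc2c(F)ccc3c2CCO3)n2cnnc12`: 4000 nM

Going by the values given here, in a physicochemical assay for solubility, read by LC-MS, in phosphate buffer, with a stated time of 24 h, at pH 7.4 (a lower number here means a less soluble compound, a higher number a more soluble compound), compound 3 gives 4000 nM, the only actual number among the three. For compound 1 the value < 1000 nM is a limit of this assay, not a number. For compound 2 the value < 2000 nM is likewise a limit. Among the compounds with values here, the one measured step, an at least 4.0-fold higher number from compound 1 to compound 3 (0.60 log units; beyond the scatter), shows that replacing the open amide group of compound 1 with the ring-closed group of compound 3 raised solubility.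

Compound 4, `O=C1CC2(CC2)CN1c1cnc(NCc2c(F)ccc3c2CCO3)n2cnnc12`, is not yet measured. It differs from compound 3 by a group of 8 heavy atoms (6 carbon, 1 nitrogen, 1 oxygen; one three-membered non-aromatic ring of carbon only, one five-membered non-aromatic ring with 1 hetero atom) in place of a group of 10 heavy atoms (8 carbon, 1 nitrogen, 1 oxygen; one five-membered non-aromatic ring with 1 hetero atom, one six-membered aromatic ring of carbon only), on an aromatic carbon. Within the data shown here, no measured step touches this particular exchange, so the step of an at least 4.0-fold higher number from compound 1 to compound 3 (0.60 log units; beyond the scatter) only hints that changes at this position can move solubility noticeably. Removing the six-membered aromatic ring and adding the three-membered ring is therefore an open question here.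

My expectation is a small rise, though it may well fall within the scatter: I estimate compound 4 at 8000 nM, with a range of 3000 nM to 25000 nM, meaning an expected step of a 2.0-fold higher number from compound 3 to compound 4 (0.30 log units; within the scatter).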

Compound 4, solubility: 130000 nM
Compound 4: the middle estimate sits 16-fold (1.21 log units) below what was measured; measured number outside the range, above it.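

The exchange at this aromatic carbon gives a 33-fold higher number from compound 3 to compound 4 (1.51 log units; beyond the scatter) in this assay, a far larger move than the earlier at least 4.0-fold higher number from compound 1 to compound 3 (0.60 log units; beyond the scatter), so this position can shift the reading much further than the first pair suggested, and a six-membered aromatic ring of carbon only in the group is not needed for a high value. Compound 1 gives < 1000 nM, which is a limit of the assay and not a number. Even so, replacing its group with the one carrying the three-membered ring and the five-membered non-aromatic ring gives an at least 130-fold higher number from compound 1 to compound 4 (2.11 log units; beyond the scatter), which makes this the largest step shown at this position.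

Nothing shown explains why the reading moves so far. The two changes in the exchange also remain tied together, so the five-membered non-aromatic ring alone, without the three-membered ring or the six-membered aromatic ring, would help to separate them, while an amine or a carboxylic acid on that ring would test whether the high value holds when the group is changed further.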